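From Chloro to Nitro on the Phenylpiperazine Arm

The source may hold more compounds than are shown below. What is called first, only, known or untested is meant among the compounds shown, and "the series" means these compounds.

Of the compounds shown here, two sharing one core have so far been measured in a functional assay on A549 cells (Homo sapiens) for inhibition, read by MTT assay, with a stated time of 72 h; on this read-out higher numbers stand for weaker inhibition and lower numbers for stronger inhibition. Compound 1 `O=C1Nc2cccc(Br)c2/C1=N/NC(=S)N1CCN(c2ccccc2)CC1` gives 54000 nM. Compound 2 `O=C1Nc2ccc(Cl)cc2/C1=N/NC(=S)N1CCN(c2ccccc2Cl)CC1` gives 7920 nM, the lower of the two numbers; its nearest neighbour is compound 1, whose number is higher by a margin beyond the scatter. Among the compounds with values here, no step between measured compounds that differ in one place is available. Compound 3 `O=C1Nc2ccc(Cl)cc2/C1=N/NC(=S)N1CCN(c2ccccc2[N+](=O)[O-])CC1` is not yet measured. It differs from compound 2 by nitro in place of chloro on an aromatic carbon, a nitro in place of chloro on an aromatic carbon, ortho to a large group. Within the data shown here, with no comparable step among the measured pairs, the expected size of the step in this assay is none beyond the scatter, in either direction. Compound 3 is therefore estimated at 9000 nM, with a range from 3000 nM to 30000 nM. This estimate means a step of a 1.1-fold higher number from compound 2 to compound 3 (0.06 log units; within the scatter) that is expected to stay within the scatter.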

Compound 3, half-maximal inhibitory concentration: 5580 nM
Estimate against measurement, compound 3: 1.6-fold (0.21 log units) above, within the range that was stated.
By their numbers in this assay, from the lowest: compounds 3 and 2 (each within the scatter of the next); then compound 1.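

In this assay the change from 2-chlorophenyl to 2-nitrophenyl comes out as a 1.4-fold lower number from compound 2 to compound 3 (0.15 log units; within the scatter) and gives the series its first step that can be read at a single place. On this aromatic carbon, ortho to a large group, three heavy atoms with two hydrogen-bond acceptors can thus enter for a single chlorine while the number stays within the scatter, so compound 2 and compound 3 cannot be told apart here. Nothing measured bears on why these two groups read alike.

Going by these compounds, whether an amine or a carboxylic acid on the same carbon would also stay within the scatter remains open. On these data alone, compound 1 differs from compound 2 in more than one place, so what the substituent on this arm contributes, compared with plain phenyl, also remains open.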